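This account rests on a few compounds, and the source may have more. Where it says the series, first, only, none or still open, it means among the compounds named here.

- Compound 1 `COc1cc2ncnc(Nc3ccc(F)c(Cl)c3)c2cc1NC(=O)N/N=C/c1ccc(C#N)cc1`: 36500 nM
- Compound 2 `COc1ccc(/C=N/NC(=O)Nc2cc3c(Nc4ccc(F)c(Cl)c4)ncnc3cc2OC)cc1`: 16500 nM

Within the data shown here, in a functional assay on PC-3 cells (Homo sapiens) for cytotoxicity, read by MTT assay, with a stated time of 72 h (on this read-out lower numbers stand for stronger inhibition and higher numbers for weaker inhibition), compound 2 gives 16500 nM, the lower of the two numbers so far, while compound 1 gives 36500 nM. Both values are high, so neither compound is strongly cytotoxic to these cells.

The next compound to be tested is compound 3 `COc1cc2ncnc(Nc3ccc(F)c(Cl)c3)c2cc1NC(=O)N/N=C/c1cc(OC)c(OC)c(OC)c1`. It has 3,4,5-trimethoxyphenyl in place of 4-methoxyphenyl on a carbon with a double bond to nitrogen. The rest of the molecule stays the same.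

Among the measured compounds shown here, only one measured step bears on this change, and it does so loosely. It is a 2.2-fold lower number from compound 1 to compound 2 (0.34 log units; beyond the scatter), a modest change that came with methoxy in place of cyano on an aromatic carbon. That step concerns the same ring, but it is a different swap, and a single step establishes no trend. A small shift towards a lower number is therefore the most that can be expected in this assay.

The expected change is a 1.4-fold lower number from compound 2 to compound 3 (0.14 log units; within the scatter). For compound 3 the estimated value is 12000 nM, with an expected range from 4000 nM to 35000 nM.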

Compound 3, half-maximal inhibitory concentration: 36500 nM
The estimate for compound 3 lay 3.0-fold (0.48 log units) below the measured number; measured number above the stated range.
By their numbers in this assay, from the lowest: compound 2; then compounds 1 and 3 (each within the scatter of the next).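

In this assay, the small gain that came with a methoxy group on this ring does not grow when more are added: 3,4,5-trimethoxyphenyl in place of 4-methoxyphenyl gives a 2.2-fold higher number from compound 2 to compound 3 (0.34 log units; beyond the scatter) in the opposite direction to the earlier step. Set against the nitrile-bearing ring, the same group gives no change at the digits printed from compound 1 to compound 3 (within the scatter), so at this place, on a carbon with a double bond to nitrogen, compound 2 stands apart from the other two, and more methoxy groups on the ring do not bring a lower number. Nothing available on these compounds accounts for the number rising again.

The compounds shown leave open whether it is the count of methoxy groups or where they sit on the ring that matters, since the step changes both at once. They also leave open how this ring would behave with an amine such as dimethylamino or with a carboxylic acid in place of the methoxy group, and whether any such change could bring the numbers far below the high values seen so far.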